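The compounds below may be only part of what the source reports. "The series", "measured", "known", "first", "only" and "open" are said of these compounds alone.

In a functional assay on NCI-H460 cells (Homo sapiens) for cytotoxicity, read by MTT assay, with a stated time of 48 h (a higher number here means a weaker inhibitor, a lower number a stronger inhibitor), compound 1 `COc1ccc(/C=C/C(=O)/C=C/c2cc3ccccc3nc2Cl)cc1` gives > 10000 nM, which is a limit and not a number. Compound 2 `COc1ccc(/C=C/C(=O)/C=C/c2cc3ccccc3nc2Cl)c(OC)c1` gives > 10000 nM, also a limit, so it stands at the limit of > 10000 nM in this assay, at which 2 of the 2 values shown sit. Compound 3 `COc1cc(OC)c(OC)cc1/C=C/C(=O)/C=C/c1cc2ccccc2nc1Cl` differs from compound 2 by one change: methoxy in place of hydrogen on an aromatic carbon. Going by the values given here, the one measured step of the same kind, methoxy in place of hydrogen on an aromatic carbon, is a step that the two limits leave unreadable from compound 1 to compound 2. It offers no size to carry over, so no step beyond the scatter is expected in this assay. The expected step is a step that the limit leaves unreadable from compound 2 to compound 3. For compound 3 the estimate is 12000 nM, with an expected range from 4000 nM to 40000 nM.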

Compound 3, half-maximal inhibitory concentration: 3960 nM
Estimate against measurement, compound 3: 3.0-fold (0.48 log units) above, outside the stated range (below it).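

Methoxy in place of hydrogen on this aromatic carbon, ortho to a methoxy group and para to a methoxy group, gives an at least 2.5-fold lower number from compound 2 to compound 3 (0.40 log units; beyond the scatter) in this assay. Going by these compounds alone, this is the only step of this kind with a readable size, as the step between compound 1 and compound 2 cannot be read. Compound 1 and compound 2 stay at a limit, not a number: the limit of > 10000 nM in this assay, at which 2 of the 3 values shown sit.

From the compounds shown here alone, it remains open whether an amine or a longer chain such as ethoxy here would give a similar step. Also open, going by these compounds, is whether this step depends on the methoxy groups already on the ring.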